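Lengthening a Methoxyalkyl Chain on Two Related Cores

This account rests on a few compounds, and the source may have more. Where it says the series, first, only, none or still open, it means among the compounds named here.

Compound 1 `COCCNC(=C\C(=O)/C=C/c1ccc(O)cc1)/C=C/c1ccc(O)cc1` and compound 3 `COCCCNC(=C\C(=O)/C=C/c1ccc(O)cc1)/C=C/c1ccc(O)cc1` differ in one place only: methoxymethyl in place of methoxy on a saturated chain carbon, two bonds along the chain from an amine nitrogen. In a functional assay on HepG2 cells (Homo sapiens) for cytotoxicity, read by MTT assay, with a stated time of 48 h (on this read-out lower numbers stand for stronger inhibition and higher numbers for weaker inhibition), compound 1 gives 63300 nM. In this assay compound 3 gives 61900 nM. The step between them is a 1.0-fold lower number from compound 1 to compound 3 (0.01 log units; within the scatter), so lengthening the chain here changed nothing that can be told from the noise.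

Compound 2 `COCCNC(=C\C(=O)/C=C/c1ccc(O)c(OC)c1)/C=C/c1ccc(O)c(OC)c1` carries a different core; the difference between the two cores is not broken down here. In this assay compound 2 is reported only as a limit, > 100000 nM, and stands at the limit of > 100000 nM in this assay, at which 1 of the 3 values shown sits.

Compound 4 `COCCCNC(=C\C(=O)/C=C/c1ccc(O)c(OC)c1)/C=C/c1ccc(O)c(OC)c1` has not been measured. It differs from compound 2 by methoxymethyl in place of methoxy on a saturated chain carbon, two bonds along the chain from an amine nitrogen, the same change made from compound 1 to compound 3, at the same place. The step from compound 2 to compound 4 is expected to be a step that the limit leaves unreadable from compound 2 to compound 4, resting on the unmoved step a 1.0-fold lower number from compound 1 to compound 3 (0.01 log units; within the scatter) seen for compound 1 and compound 3. Compound 4 is therefore estimated at 150000 nM, most likely again reported only as a limit, within a range of 60000 nM to 400000 nM.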

Compound 4, half-maximal inhibitory concentration: > 100000 nM
Compound 4 was reported as a limit; the forecaster's own chance of this, stated with the estimate: 75%; the middle value is on the limit's open side.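

In this assay, compound 2 and compound 4 are both reported only as limits, so no step between them can be read: the limit of > 100000 nM in this assay, at which 2 of the 4 values shown sit.

The compounds shown leave open whether going from (2-methoxyethyl)amino to (3-methoxypropyl)amino changes the read-out at all on the core of compound 2.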